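The source may hold more compounds than are shown below. What is called first, only, known or untested is meant among the compounds shown, and "the series" means these compounds.

Measured so far:
compound 1, `Cc1cc(C(=O)NC(C)C)nn1Cc1cc(Cl)ccc1OCc1ccccc1`: 126 nM
compound 2, `Cc1cc(NC(=O)CC2CCCCC2)nn1Cc1cc(Cl)ccc1OCc1ccccc1`: 6.31 nM

In an assay on CHO-K1 cells for displacement of a labelled ligand from prostaglandin E2 receptor EP1 subtype (Homo sapiens) (a lower number here means a stronger inhibitor, a higher number a weaker inhibitor), compound 2 gives the lowest of the two numbers, the nearest being compound 1 by a 20-fold lower number from compound 1 to compound 2 (1.30 log units; beyond the scatter). Compound 3, `Cc1cc(NC(=O)O[C@H]2CCOC2)nn1Cc1cc(Cl)ccc1OCc1ccccc1`, keeps the core of compound 2 and differs by (oxolan-3-yl)oxy in place of cyclohexylmethyl on a carbonyl carbon. Going by the values given here, the only measured step, a 20-fold lower number from compound 1 to compound 2 (1.30 log units; beyond the scatter), changes the group on the ring in the opposite sense and does not bear directly on this replacement. Compound 3 is therefore expected to land somewhat above compound 2 in this assay, by a 3.2-fold higher number from compound 2 to compound 3 (0.50 log units; beyond the scatter), with wide uncertainty. The estimate for compound 3 is 20 nM, between 5 nM and 80 nM.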

Compound 3, half-maximal inhibitory concentration: 79.4 nM
The estimate for compound 3 lay 4.0-fold (0.60 log units) below the measured number; the range from low to high includes it.
By their numbers in this assay, from the lowest: compound 2; then compounds 3 and 1 (each within the scatter of the next).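

On the carbonyl carbon, (oxolan-3-yl)oxy in place of cyclohexylmethyl gives up most of the advantage of compound 2 in this assay (a 13-fold higher number from compound 2 to compound 3 (1.10 log units; beyond the scatter)). Against the isopropylcarbamoyl group, the (((oxolan-3-yl)oxy)carbonyl)amino group shows no separation (a 1.6-fold lower number from compound 1 to compound 3 (0.20 log units; within the scatter)), so an amide-type nitrogen on that aromatic carbon does not by itself give the low number of compound 2. Nothing available accounts for this loss.

The change replaces both the ring and the atom joining it to the carbonyl, and the compounds shown do not separate the two. A cyclohexyloxy or an (oxolan-3-yl)methyl group would do so.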